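The source may report more compounds than this note shows. Statements on the series, on what has been measured and on what is new or still open speak of the compounds shown alone.

Compound 1 `O=C1CCC(N2C(=O)c3cccc(Nc4ccccc4)c3C2=O)C(=O)N1`: 4%
Compound 2 `CCc1ccc(Nc2ccc3c(c2)C(=O)N(C2CCC(=O)NC2=O)C3=O)cc1`: 5%

In an assay on FRT-Jurkat cells for inhibition of nuclear factor NF-kappa-B complex (Homo sapiens), read by flow cytometry, with a stated time of 24 h, tested at 10 uM (a lower number here means less inhibition, a higher number more inhibition at the concentration tested (going by the name of the read-out)), compound 1 gives 4% and compound 2 gives 5%; the two sit within the scatter of each other, so neither stands apart, and both lie near the bottom of the percentage scale. Compound 3 `O=C1CCC(N2C(=O)c3cccc(Nc4ccc(O)cc4)c3C2=O)C(=O)N1` differs from compound 1 by hydroxy in place of hydrogen on an aromatic carbon. For the measured compounds named here, no step between measured compounds is known here. The step of a number 2 percentage points higher from compound 1 to compound 3 (within the scatter) is expected to be small, with no change beyond the scatter in either direction. Compound 3 is expected to give 6%, between -8% and 25%.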

Compound 3, a percentage reported as inhibition, at one concentration (the size of the read-out at that concentration, not a potency): 4%
Compound 3: the middle estimate sits 2 percentage points above what was measured; the measured number falls inside the stated range.
By their numbers in this assay, from the lowest: compounds 1, 3 and 2 (each within the scatter of the next).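

In this assay, hydroxy in place of hydrogen on the aromatic carbon para to a large group gives no change at the digits printed from compound 1 to compound 3 (within the scatter). For the compounds shown here, this is the first single change that can be read at this position, and phenyl to 4-hydroxyphenyl does not separate the two compounds: compound 3 also stays near the bottom of the percentage scale. No other measurement here helps to interpret this result. From the compounds shown here alone, whether an amine or a carboxylic acid at this same place would move the number beyond the scatter remains open, and so does the effect of hydroxy on another carbon of this ring.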